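Swapping methyl for cyclopropyl on a sulfonyl sulfur

This account rests on a few compounds, and the source may have more. Where it says the series, first, only, none or still open, it means among the compounds named here.

In a functional assay on HCC827 cells (Homo sapiens) for antiproliferative activity, read by MTT assay, with a stated time of 72 h (a lower number here means a stronger inhibitor, a higher number a weaker inhibitor), compound 1 `CN1CCN(c2ccc(Nc3ncc4nc(Nc5ccc(F)cc5)n([C@@H]5CCN(C(=O)CO)C5)c4n3)cc2)CC1` gives 350 nM and compound 2 `CN1CCN(c2ccc(Nc3ncc4nc(Nc5ccccc5)n([C@H]5CCNC5)c4n3)cc2)CC1` gives 530 nM while compound 3 `CN1CCN(c2ccc(Nc3ncc4nc(Nc5ccccc5)n([C@H]5CCN(S(C)(=O)=O)C5)c4n3)cc2)CC1` gives 17 nM as the lowest number of the three. Compound 4 `CN1CCN(c2ccc(Nc3ncc4nc(Nc5ccccc5)n([C@H]5CCN(S(=O)(=O)C6CC6)C5)c4n3)cc2)CC1` has not been measured yet. It keeps the structure of compound 3 except for cyclopropyl in place of methyl on a sulfonyl sulfur. Going by the values given here, only one measured step bears on this spot: a 31-fold lower number from compound 2 to compound 3 (1.49 log units; beyond the scatter) came with methylsulfonyl in place of hydrogen on an amine nitrogen in a ring. That step compares a sulfonyl group with none. Among the compounds with values here, no measured pair compares two groups on the sulfur, and compound 4 keeps the sulfonyl group, so the large size of that step does not carry over. The step expected here is a 1.2-fold higher number from compound 3 to compound 4 (0.07 log units; within the scatter) and so none beyond the scatter in this assay is expected. With so little direct evidence the range stays wide. Compound 4 is estimated at 20 nM (expected range 7 nM to 60 nM).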

Compound 4, half-maximal inhibitory concentration: 1.6 nM
Estimate against measurement, compound 4: 13-fold (1.10 log units) above; the whole stated range lies above it.
By their numbers in this assay, from the lowest: compound 4; then compound 3; then compounds 1 and 2 (each within the scatter of the next).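

In this assay the group on the sulfonyl sulfur matters in its own right, not only the presence of a sulfonyl group: cyclopropyl in place of methyl brings an 11-fold lower number from compound 3 to compound 4 (1.03 log units; beyond the scatter) for a swap of 1 heavy atom for 3 heavy atoms, all carbon. Measured against the free amine, cyclopropylsulfonyl in place of hydrogen brings a 330-fold lower number from compound 2 to compound 4 (2.52 log units; beyond the scatter) and so goes well past the step with methylsulfonyl, which was a 31-fold lower number from compound 2 to compound 3 (1.49 log units; beyond the scatter) on the same nitrogen. Nothing measured here explains why cyclopropyl does so much better than methyl on this sulfur.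

The compounds shown leave open whether this gain needs the three-membered ring or would also come with an open chain such as ethyl or isopropyl. They also leave open how a larger ring, such as cyclobutyl or phenyl, would fare on the sulfur.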